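Removing the methyl from the ether oxygen of compound 2

This account rests on a few compounds, and the source may have more. Where it says the series, first, only, none or still open, it means among the compounds named here.

Compound 2 `COc1cc(C)cc(-c2nn(CC#N)cc2-c2ccnc(-c3ccc(N(C)C)cc3)c2)c1` and compound 1 `Cc1cc(O)cc(-c2nn(CC#N)cc2-c2ccnc(-c3ccc(Oc4ccccc4)cc3)c2)c1` were both tested in a functional assay on BT-549 cells (Homo sapiens) for cytotoxicity, read by sulforhodamine B assay, with a stated time of 48 h, tested at 0.01 uM; a lower number here means a stronger effect, a higher number a weaker effect of the compound at the concentration tested. Compound 2 gives 100% and compound 1 gives 91%; the two values lie within the scatter of each other, so neither stands apart from the other. Compound 3 `Cc1cc(O)cc(-c2nn(CC#N)cc2-c2ccnc(-c3ccc(N(C)C)cc3)c2)c1` has not yet been measured. It differs from compound 2 by hydrogen in place of methyl on an oxygen on an aromatic ring. Among the measured compounds shown here, the two measured values sit close together, and no measured step covers this change, so the change is expected to bring no step beyond the scatter, a number 5 percentage points lower from compound 2 to compound 3 (within the scatter). Compound 3 is expected to give 95%, within a range from 82% to 105%.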

Compound 3, a percentage reported as activity, at one concentration (the size of the read-out at that concentration, not a potency): 91%
Estimate against measurement, compound 3: 4 percentage points above; the range from low to high includes it.
By their numbers in this assay, from the lowest: compounds 1, 3 and 2 (each within the scatter of the next).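

In this assay, among the compounds shown here, hydrogen in place of methyl on the oxygen gives a number 9 percentage points lower from compound 2 to compound 3 (within the scatter), the first measured step at this position, so methoxy and hydroxy are not told apart here. Dimethylamino in place of phenoxy on an aromatic carbon gives no change at the digits printed from compound 1 to compound 3 (within the scatter), so with the hydroxy group present, these two groups are not told apart either. On these data alone, whether an ethoxy group, or an amine or carboxylic acid in place of the hydroxy, would give a step beyond the scatter remains open. Nothing available explains why these compounds read alike.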